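A few compounds are considered here, and "the series" means these few. Any claim that something is new, unique, unknown or untested is made for them only; others in the source may bear on it.

Compound 1 `CC(C)[C@@H](C[C@H]1SC(=O)NC1=O)c1ccc(-c2ccc3cccc(F)c3c2)[nH]c1=O` gives 25.5 10^-6 cm/s in an ADME assay on MDCK cells (Canis lupus familiaris) for permeability, in the apical to basolateral direction; on this read-out lower numbers stand for lower permeability and higher numbers for higher permeability.
Compound 2 `CC(C)[C@H](C[C@H]1OC(=O)NC1=O)c1ccc(-c2ccc3cccc(F)c3c2)[nH]c1=O` gives 10.3 10^-6 cm/s in this assay.
Compound 3 `CC(C)/C(=C1\C(=O)NC(=O)N1C)c1ccc(-c2ccc3cccc(F)c3c2)[nH]c1=O` gives 6.85 10^-6 cm/s in this assay.

Among these three numbers compound 2 stands second highest. Its nearest neighbour is compound 3, whose number lies within the scatter of that of compound 2, so no order can be read between them; compound 1 stands beyond the scatter above compound 2. Compound 4 `CC(C)[C@@H](c1ccc(-c2ccc3cccc(F)c3c2)[nH]c1=O)[C@H]1OC(=O)NC1=O` has not yet been measured in this assay. It differs from compound 2 in one place: 2,4-dioxo-1,3-oxazolidin-5-yl in place of (2,4-dioxo-1,3-oxazolidin-5-yl)methyl on a saturated chain carbon bound to an aromatic carbon and a saturated chain carbon. Among the compounds with values here, no measured pair shows this change, so its effect is unknown. A small downward step in this assay, within the scatter, is expected. Compound 4 is expected to give 8 10^-6 cm/s in this assay, between 4 10^-6 cm/s and 16 10^-6 cm/s. The expected step is a 1.3-fold lower number from compound 2 to compound 4 (0.11 log units; within the scatter).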

Compound 4, apparent permeability: 9.14 10^-6 cm/s
The estimate for compound 4 lay 1.1-fold (0.06 log units) below the measured number, and the stated range covers the measured number.
By their numbers in this assay, from the lowest: compounds 3, 4 and 2 (each within the scatter of the next); then compound 1.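

Within the data shown here, this is the first measured pair that differs in one place, and it isolates the methyl link. Going from (2,4-dioxo-1,3-oxazolidin-5-yl)methyl to 2,4-dioxo-1,3-oxazolidin-5-yl on this saturated chain carbon gives a 1.1-fold lower number from compound 2 to compound 4 (0.05 log units; within the scatter) in this assay. At this position, then, the shorter attachment leaves the read-out indistinguishable from that of the methyl-linked ring. Going by these compounds, whether a longer chain carrying the same ring, or an amine or a carboxylic acid in place of the ring, would also stay within the scatter remains open. No measured finding on hand explains this step.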